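This account rests on a few compounds, and the source may have more. Where it says the series, first, only, none or still open, it means among the compounds named here.

Within the data shown here, in a functional assay on isolated protein for antagonist activity at Oxoeicosanoid receptor 1 (Homo sapiens), read by fluorescence and calcium flux, with stated times of 2 min and 1 min (on this read-out higher numbers stand for weaker inhibition and lower numbers for stronger inhibition), compound 1 `O=C(O)CCCC(=O)n1ccc2ccc(Cl)cc21` gives 400 nM, the lowest of the two numbers known so far. The other measured compound, compound 2 `CCCCCCc1cn(C(=O)CCCC(=O)O)c2ccccc12`, gives 20700 nM in this assay, and the gap between these two values lies well beyond the scatter. Compound 3 `O=C(O)CCCC(=O)n1ccc2ccccc21` differs from compound 1 by one change, (hydrogen in place of chloro on an aromatic carbon), which here means hydrogen in place of chloro on an aromatic carbon. Nothing measured isolates this change, so the step from compound 1 to compound 3 is expected to be modest and toward weaker inhibition, as a 3.0-fold higher number from compound 1 to compound 3 (0.48 log units; beyond the scatter) expresses. Compound 3 is therefore estimated at 1200 nM, with a likely range from 350 nM to 4000 nM.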

Compound 3, half-maximal inhibitory concentration: > 30000 nM
Compound 3: a limit, no number; the forecaster's own chance of this, stated with the estimate: 5%; at least 25-fold (1.39 log units) between middle value and limit.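

Compound 3 appears only as a limit of the assay, not as a number: the limit of > 30000 nM in this assay, at which 1 of the 3 values shown sits. Hydrogen in place of chloro on this aromatic carbon gives an at least 75-fold higher number from compound 1 to compound 3 (1.87 log units; beyond the scatter), a large step, so much of the inhibition seen with compound 1 depends on this one position. Hydrogen in place of hexyl gives an at least 1.4-fold higher number from compound 2 to compound 3 (0.16 log units; that floor lies within the scatter), so this comparison sets no order between those two compounds.

Still open, on these data alone, is whether chloro is special here, or whether fluoro, bromo or methyl on the same aromatic carbon would keep the inhibition.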